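The source may hold more compounds than are shown below. What is called first, only, known or untested is meant among the compounds shown, and "the series" means these compounds.

Within the data shown here, compound 2 `COc1ccc(NC(=O)Nc2cccc(CNc3ncnc4cc(OC)c(OC)cc34)c2)cc1` is the only compound of this set with a definite number in a functional assay on MGC-803 cells (Homo sapiens) for antiproliferative activity, read by MTT assay; on this read-out lower numbers stand for stronger inhibition and higher numbers for weaker inhibition; in that assay compound 2 gives 12300 nM. Compound 1 `COc1cc2ncnc(NCc3cccc(NC(=O)Nc4ccccc4C)c3)c2cc1OC` reaches only a limit of this assay, > 50000 nM. Among the measured compounds shown here, the one measured step, an at least 4.0-fold lower number from compound 1 to compound 2 (0.60 log units; beyond the scatter), therefore rests on that limit (the limit of > 50000 nM in this assay, at which 1 of the 2 values shown sits). Compound 3 `COc1cc2ncnc(NCc3cccc(NC(=O)Nc4ccccc4F)c3)c2cc1OC` carries 2-fluorophenyl in place of 4-methoxyphenyl on an amide-type nitrogen, returning to a 2-substituted phenyl like that of compound 1. For the measured compounds named here, since the only comparable step ran toward weaker inhibition for 2-methylphenyl, compound 3 is expected to show a 2.4-fold higher number from compound 2 to compound 3 (0.39 log units; beyond the scatter), around an estimated 30000 nM within 10000 nM to 90000 nM.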

Compound 3, half-maximal inhibitory concentration: 10300 nM
The estimate for compound 3 lay 2.9-fold (0.46 log units) above the measured number, and the stated range covers the measured number.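

In this assay, 2-fluorophenyl in place of 4-methoxyphenyl on the amide-type nitrogen gives a 1.2-fold lower number from compound 2 to compound 3 (0.08 log units; within the scatter), so these two different phenyl groups cannot be told apart at this position. Fluoro in place of methyl on an aromatic carbon gives an at least 4.8-fold lower number from compound 1 to compound 3 (0.68 log units; beyond the scatter), which shows that a 2-substituted phenyl as such does not go with the weak end of this series. That step rests on a limit, the one reached by compound 1: the limit of > 50000 nM in this assay, at which 1 of the 3 values shown sits.

Open remains how an unsubstituted phenyl, a pyridyl ring or a phenyl bearing a carboxylic acid would read on this nitrogen. Also open, going by these compounds, is whether any group here moves the number far from those of compound 2 and compound 3.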